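Lengthening the Acid-Bearing Tail of a Lipopeptide Agonist

The compounds below may be only part of what the source reports. "The series", "measured", "known", "first", "only" and "open" are said of these compounds alone.

Compound 1, `CCCCCCCCCCCC(=O)OC[C@H](CSC[C@@H](N)C(=O)NCCO)OC(=O)CCCCCCCCCCC`: 24 nM
Compound 2, `CCCCCCCCCCCC(=O)OC[C@H](CSC[C@@H](N)C(=O)NCCCC(C)(C)CO)OC(=O)CCCCCCCCCCC`: 30700 nM
Compound 3, `CCCCCCCCCCCC(=O)OC[C@H](CSC[C@@H](N)C(=O)NCCCCCC(=O)O)OC(=O)CCCCCCCCCCC`: 108 nM

In an assay on HEK293 cells for agonist activity at Toll-like receptor 2 (Homo sapiens) (a higher number here means that more compound is needed for the effect, a lower number that less compound is needed), compound 3 stands second highest of the three numbers; compound 1 lies nearest, and compound 2 lies furthest, as a 280-fold lower number from compound 2 to compound 3 (2.45 log units; beyond the scatter) shows. Compound 4 is `CCCCCCCCCCCC(=O)OC[C@H](CSC[C@@H](N)C(=O)NCCOCCOCCOCCC(=O)O)OC(=O)CCCCCCCCCCC`, and it differs from compound 3 in one place: 2-(2-(2-carboxyethoxy)ethoxy)ethoxy in place of 3-carboxypropyl on a saturated chain carbon, two bonds along the chain from an amide-type nitrogen. The terminal carboxylic acid stays; only the stretch between the amide-type nitrogen and that acid grows. Within the data shown here, two measured steps bear on this. a 4.5-fold higher number from compound 1 to compound 3 (0.65 log units; beyond the scatter) shows that adding a carboxylic-acid tail costs only modestly, whereas a 1300-fold higher number from compound 1 to compound 2 (3.11 log units; beyond the scatter) shows that a 2-(hydroxymethyl)-2-methylpropyl group costs heavily. Among the measured compounds shown here, no measured step tests a longer acid-ended tail. A modest step is therefore expected in this assay, a 1.7-fold higher number from compound 3 to compound 4 (0.22 log units; within the scatter), and compound 4 is estimated at 180 nM, with a range from 40 nM to 800 nM.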

Compound 4, half-maximal effective concentration: 900 nM
For compound 4 the middle estimate is 5.0-fold (0.70 log units) below the measured one; measured number above the stated range.
By their numbers in this assay, from the lowest: compound 1; then compound 3; then compound 4; then compound 2.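

In this assay the acid-ended tail cannot simply be lengthened freely, since keeping the terminal carboxylic acid does not hold the number when 2-(2-(2-carboxyethoxy)ethoxy)ethoxy replaces 3-carboxypropyl, with an 8.3-fold higher number from compound 3 to compound 4 (0.92 log units; beyond the scatter) as the cost. Against the hydroxy end the loss is now a 38-fold higher number from compound 1 to compound 4 (1.57 log units; beyond the scatter) in size, yet the long acid tail still does far better than the 2-(hydroxymethyl)-2-methylpropyl group, with a 34-fold lower number from compound 2 to compound 4 (1.53 log units; beyond the scatter) as the gain. No evidence on the reason for these shifts is at hand. As far as these compounds go, whether a longer all-carbon chain ending in a carboxylic acid would cost as much stays open, and so does the effect of an amine at the chain end.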